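Chain variation on the compound 2 scaffold: bioavailability outlook

The source may report more compounds than this note shows. Statements on the series, on what has been measured and on what is new or still open speak of the compounds shown alone.

Measured so far:
compound 1, `C[C@@H](Cn1c(=O)[nH]/c(=N\c2ccc(Oc3nccs3)cc2)n(Cc2ccc(Cl)cc2)c1=O)C(=O)O`, gives 41.4% in an ADME assay on the whole organism (Rattus norvegicus) for pharmacokinetics, using cassette dosing, at a dose of 1 mg/kg by the oral route; a lower number here means that a smaller share of the oral dose reaches the circulation, a higher number that a larger share of the oral dose reaches the circulation
compound 2, `CC(C)Oc1ccc(/N=c2\[nH]c(=O)n(CC(C)(C)C(=O)O)c(=O)n2Cc2ccc(Cl)cc2)cc1Cl`, gives 85.3% in this assay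
compound 3, `C[C@@H](Cn1c(=O)[nH]/c(=N\c2ccc(Oc3ccccn3)cc2)n(Cc2ccc(Cl)cc2)c1=O)C(=O)O`, gives 52.8% in this assay

Compound 2 stands highest of the three numbers in this assay, beyond the scatter from compound 3 and further still from compound 1. Within the data shown here, the only single-point step measured so far is a number 11.4 percentage points higher from compound 1 to compound 3 (beyond the scatter); it concerns the group on the aryl ether oxygen and says nothing about the acid-bearing chain.

Compound 4, `CC(C)Oc1ccc(/N=c2\[nH]c(=O)n(C[C@H](C)C(=O)O)c(=O)n2Cc2ccc(Cl)cc2)cc1Cl`, differs from compound 2 as follows: 1-carboxyethyl in place of 1-carboxy-1-methylethyl on a saturated chain carbon bound to an aromatic nitrogen. Among the measured compounds shown here, no measured pair isolates this change. Compounds 1 and 3 carry the 1-carboxyethyl chain and sit well below compound 2, but both also differ from compound 2 at the other aromatic ring, so their lower numbers cannot be read as the effect of the chain alone. The expectation therefore rests on compound 2 as anchor, with a wide range to cover the unknown contribution of the chain.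

A step of a number 20.3 percentage points lower from compound 2 to compound 4 (beyond the scatter) is expected in this assay, downward but uncertain in size. Compound 4 is estimated at 65%, with a range from 40% to 90%.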

Compound 4, oral bioavailability: 82.4%
Compound 4: middle estimate off by 17.4 percentage points, on the low side, and the stated range covers the measured number.
By their numbers in this assay, from the lowest: compound 1; then compound 3; then compounds 4 and 2 (each within the scatter of the next).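

Among these compounds, this is the first measured pair that isolates the acid-bearing chain on a saturated chain carbon bound to an aromatic nitrogen: in this assay, 1-carboxyethyl in place of 1-carboxy-1-methylethyl gives a number 2.9 percentage points lower from compound 2 to compound 4 (within the scatter), so the chain can go from 6 to 5 heavy atoms and gain a defined stereocentre with no readable change in the share of the oral dose reaching the circulation. Compound 4 carries the same 1-carboxyethyl chain as compounds 1 and 3, so on this scaffold that chain is compatible with compound 4 giving 82.4%, and the second methyl of the 1-carboxy-1-methylethyl group is not needed to hold the read-out in this pair. No measurement shown here gives a reason why the read-out holds across this change.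

Still open, going by these compounds, is whether the same tolerance extends to a longer chain, such as 3-carboxypropyl, or to a primary amide or a tetrazole in place of the carboxylic acid at this position. Also open, on these data alone, is how the opposite stereocentre of the 1-carboxyethyl chain would read in this assay, since compound 4 represents one defined form only.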